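Bromothiophene analogue of a bicyclic amine: cytotoxicity outlook

The source may report more compounds than this note shows. Statements on the series, on what has been measured and on what is new or still open speak of the compounds shown alone.

Compound 1, `Cc1ccsc1CN[C@@H]1C[C@H]2C[C@@H]([C@H]1C)C2(C)C`, gives 10000 nM in an ADME assay on MDCK cells (Canis lupus familiaris) for cytotoxicity, read by microscopy, with a stated time of 48 h; on this read-out higher numbers stand for lower toxicity in this test and lower numbers for higher toxicity in this test.
Compound 2, `CCc1ccsc1CN[C@@H]1C[C@H]2C[C@@H]([C@H]1C)C2(C)C`, gives 25000 nM in this assay.
Compound 3, `C[C@H]1[C@H](NCc2sccc2C2CCCC2)C[C@H]2C[C@@H]1C2(C)C`, gives 12500 nM in this assay.

Among these three numbers, compound 1 stands lowest. Within the data shown here, its nearest neighbour is compound 3, reached by a 1.3-fold higher number from compound 1 to compound 3 (0.10 log units; within the scatter), and its furthest is compound 2, reached by a 2.5-fold higher number from compound 1 to compound 2 (0.40 log units; beyond the scatter); only the step to compound 2 lies beyond the scatter, and it is modest.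

The unmeasured compound 4, `C[C@H]1[C@H](NCc2cc(Br)cs2)C[C@H]2C[C@@H]1C2(C)C`, differs from compound 1 by 4-bromothiophen-2-yl in place of 3-methylthiophen-2-yl on a saturated chain carbon bound to an amine nitrogen. The measured steps all alter the group on the aromatic carbon of the thiophene, and none of them introduces bromine or removes the 3-methyl group, so they bear on the present change only loosely. They show that changes at the thiophene move the number little: one step within the scatter and one modest step upward. No larger shift is therefore expected for compound 4, and the estimated step of a 1.3-fold higher number from compound 1 to compound 4 (0.10 log units; within the scatter) is expected to stay within the scatter. The value for compound 4 is estimated at 12500 nM, with a range from 5000 nM to 30000 nM.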

Compound 4, minimum cytotoxic concentration: 6250 nM
Estimate against measurement, compound 4: 2.0-fold (0.30 log units) above; low and high end bracket the measured number.
By their numbers in this assay, from the lowest: compounds 4, 1, 3 and 2 (each within the scatter of the next, the first and the last beyond it).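

In this assay, 4-bromothiophen-2-yl in place of 3-methylthiophen-2-yl gives a 1.6-fold lower number from compound 1 to compound 4 (0.20 log units; within the scatter) and so leaves the read-out within the usual scatter. The earlier compounds shown here varied only the alkyl or cycloalkyl group on the aromatic carbon, while compound 4 shows that this exchange on a saturated chain carbon bound to an amine nitrogen, which brings in bromine and removes the methyl group, also produces no step beyond the scatter from compound 1. Nothing available accounts for this result.

Left open is how much of the step belongs to the bromine and how much to the loss of the methyl group, which an unsubstituted thiophen-2-yl would help to separate. Also open, from the compounds shown here alone, is whether an amine or a carboxylic acid on the thiophene would move the number beyond the scatter.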